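The compounds below may be only part of what the source reports. "The series", "measured", "known", "first", "only" and "open" are said of these compounds alone.

In an ADME assay on MT4 cells (Homo sapiens) for cytotoxicity, read by MTT assay, with a stated time of 4 days (on this read-out higher numbers stand for lower toxicity in this test and lower numbers for higher toxicity in this test), compound 2 `CCOC(=O)c1cnc(N2CCN(Cc3ccccc3[N+](=O)[O-])CC2)nc1Oc1c(C)cc(-c2ccc(C#N)cc2)cc1C` gives >= 78700 nM, a limit of the assay rather than a measured number. Compound 1 `CCOC(=O)c1cnc(N2CCN(Cc3ccc(Br)cc3)CC2)nc1Oc1c(C)cc(-c2ccc(C#N)cc2)cc1C` gives > 125000 nM, which is also a limit. The step that the two limits leave unreadable from compound 1 to compound 2 therefore cannot be read. Compound 3 `CCOC(=O)c1cnc(N2CCN(Cc3ccc(C(N)=O)cc3)CC2)nc1Oc1c(C)cc(-c2ccc(C#N)cc2)cc1C` differs from compound 2 by 4-carbamoylphenyl in place of 2-nitrophenyl on a saturated chain carbon bound to an amine nitrogen in a ring. Both measured values sit at limits, so no readable step bears on this change, and the expected step that the limit leaves unreadable from compound 2 to compound 3 is none beyond the scatter. Compound 3 is estimated at 100000 nM, with a range from 40000 nM to 250000 nM, most likely reported again as a limit.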

Compound 3, half-maximal cytotoxic concentration: 66500 nM
The estimate for compound 3 lay 1.5-fold (0.18 log units) above the measured number; measured number inside the range.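

Among these compounds, compound 3 gives the first real number at this position in this assay, since compound 1 and compound 2 each stand only at a limit, and the step between those two cannot be read. Putting 4-carbamoylphenyl in place of 2-nitrophenyl gives an at least 1.1-fold lower number from compound 2 to compound 3 (0.07 log units; that floor lies within the scatter) here, and carbamoyl in place of bromo gives an at least 1.8-fold lower number from compound 1 to compound 3 (0.27 log units; that floor lies within the scatter) here. On these data alone, both are only floors, so the true size of each change stays unknown.

As far as these compounds go, it remains open whether a carboxylic acid or an amine in place of the carbamoyl would give a number clearly apart from these.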